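The source may hold more compounds than are shown below. What is called first, only, known or untested is meant among the compounds shown, and "the series" means these compounds.

Compounds measured so far:
Compound 1 `Cc1ccc(-n2nc(C(=O)Nc3ccc(Oc4ncnc5ccsc45)c(F)c3)c(C)cc2=O)cc1` gives 5890 nM in a functional assay on A549 cells (Homo sapiens) for cytotoxicity, read by MTT assay, with a stated time of 72 h; a lower number here means a stronger inhibitor, a higher number a weaker inhibitor.
Compound 2 `Cc1cc(=O)n(-c2ccc(F)cc2)nc1C(=O)Nc1ccc(Oc2ncnc3ccsc23)c(F)c1` gives 580 nM in this assay.
Compound 3 `Cc1cc(=O)n(-c2ccc(F)c(F)c2)nc1C(=O)Nc1ccc(Oc2ncnc3ccsc23)c(F)c1` gives 4590 nM in this assay.

Compound 2 gives the lowest of the three numbers, with compound 3 nearest and compound 1 furthest. The measured steps change only the group on the ring nitrogen: a 10-fold lower number from compound 1 to compound 2 (1.01 log units; beyond the scatter), a 7.9-fold higher number from compound 2 to compound 3 (0.90 log units; beyond the scatter) and a 1.3-fold lower number from compound 1 to compound 3 (0.11 log units; within the scatter). Compound 4 `Cc1cc(=O)n(-c2ccc(F)cc2)nc1C(=O)Nc1ccc(Oc2ncnc3sccc23)c(F)c1` keeps that part of compound 2 unchanged and instead rearranges the group on the oxygen: a group of 9 heavy atoms (6 carbon, 2 nitrogen, 1 sulfur; one five-membered aromatic ring with 1 hetero atom, one six-membered aromatic ring with 2 hetero atoms) in place of a group of 9 heavy atoms (6 carbon, 2 nitrogen, 1 sulfur; one five-membered aromatic ring with 1 hetero atom, one six-membered aromatic ring with 2 hetero atoms), on an oxygen on an aromatic ring. The two compounds have the same atoms, joined differently. Within the data shown here, none of the measured steps touches this group, so no step bears on the change, and the measurements give no guidance on its direction or size. With nothing to point either way, the expected step from compound 2 to compound 4 in this assay is a 1.4-fold higher number from compound 2 to compound 4 (0.14 log units; within the scatter), that is, none beyond the scatter, with a wide range to allow for a rearranged ring behaving differently. Compound 4 is therefore estimated at 800 nM, between 250 nM and 3000 nM.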

Compound 4, half-maximal inhibitory concentration: 2620 nM
The estimate for compound 4 lay 3.3-fold (0.52 log units) below the measured number, and the stated range covers the measured number.
By their numbers in this assay, from the lowest: compound 2; then compounds 4, 3 and 1 (each within the scatter of the next, the first and the last beyond it).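

Among these compounds, compound 4 is the first change to the group on the oxygen, as every earlier step altered only the group on the ring nitrogen. Here the atoms and the counted hydrogen-bond donors and acceptors stay the same, yet this assay gives a 4.5-fold higher number from compound 2 to compound 4 (0.65 log units; beyond the scatter). So in this series the number depends on how the two aromatic rings of this group are joined, and not only on which atoms it contains. Nothing measured here explains this difference.

The compounds shown leave open whether the rearranged group would give a similar step with 4-methylphenyl or 3,4-difluorophenyl on the ring nitrogen. They also leave open how the number would respond to an amine or a methyl group added to the group on the oxygen.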